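A few compounds are considered here, and "the series" means these few. Any claim that something is new, unique, unknown or untested is made for them only; others in the source may bear on it.

Compound 3 `CCOC(=O)c1c(N)sc(-c2cccc(C(C)=O)c2)c1-c1cccc(C(F)(F)F)c1` has been tested in a functional assay on CHO-K1 cells for agonist activity at adenosine receptor A1 (Homo sapiens), read by GTPgammaS binding (a higher number here means that more compound is needed for the effect, a lower number that less compound is needed), and gives there only a limit of the assay, > 10 uM. Compound 1 `CC(=O)c1cccc(-c2sc(N)c(C(=O)c3ccccc3)c2-c2cccc(C(F)(F)F)c2)c1` likewise gives only a limit in this assay, > 10 uM. Compound 2 `Nc1sc(-c2ccc([N+](=O)[O-])cc2)c(-c2cccc(C(F)(F)F)c2)c1C(=O)c1ccccc1` also gives only a limit, > 10 uM. The step from compound 1 to compound 2 a step that the two limits leave unreadable from compound 1 to compound 2 and the step from compound 1 to compound 3 a step that the two limits leave unreadable from compound 1 to compound 3 therefore cannot be sized. Compound 4 `CCOC(=O)c1c(N)sc(-c2ccc(OC)cc2)c1-c1cccc(C(F)(F)F)c1` differs from compound 3 by 4-methoxyphenyl in place of 3-acetylphenyl on an aromatic carbon. Neither measured step bears readably on this exchange, and the limit of > 10 uM in this assay, at which 3 of the 3 values shown sit, gives nothing from which a direction beyond the scatter could be expected. Compound 4 is estimated at 10 uM, with a range from 3 uM to 30 uM. The expected step is a number no higher from compound 3 to compound 4 (the limit leaves the size open).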

Compound 4, concentration for half-maximal effect: > 10 uM
Compound 4 ended at the assay's limit (the forecaster's own chance of this, stated with the estimate: 80%); the middle value sits exactly at the limit.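

For the compounds shown here, compound 3 and compound 4 both give only a limit in this assay, so no step between them can be read: the limit of > 10 uM in this assay, at which 4 of the 4 values shown sit. The compounds shown leave open what concentration any of them needs for the effect, and whether any exchange on the shared core changes it.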